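Swapping a Pyrazole for a Sulfonamide on a Fused Core

A few compounds are considered here, and "the series" means these few. Any claim that something is new, unique, unknown or untested is made for them only; others in the source may bear on it.

Of the compounds shown here, two have been tested in a functional assay on CHO cells for agonist activity at Alpha-1D adrenergic receptor (Homo sapiens), read by FLIPR and calcium flux; a lower number here means that less compound is needed, a higher number that more compound is needed for the effect. Compound 1 `Cc1c(OCC2=NCCN2)ccc(Cl)c1NS(C)(=O)=O` carries a methylsulfonyl amino group on a chlorinated, methylated benzene ring. In this assay compound 1 gives > 10000 nM, which is a limit of the assay rather than a number. Compound 2 `Cn1nccc1-c1cccc2c1CCC2c1ncc[nH]1` has a different core, a fused two-ring system bearing a 1-methyl-1H-pyrazol-5-yl group. In this assay compound 2 gives > 10000 nM, again a limit and not a number. Both values therefore sit at the same place, described by the limit of > 10000 nM in this assay, at which 2 of the 2 values shown sit, so compound 2 stands no lower and no higher than compound 1 as far as the numbers show.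

Compound 3 `CCS(=O)(=O)Nc1cccc2c1CCC2c1ncc[nH]1` keeps the core of compound 2 and changes one group: (ethylsulfonyl)amino in place of 1-methyl-1H-pyrazol-5-yl on an aromatic carbon. For the measured compounds named here, with no measured step between compounds available, the size of the step is uncertain. The step from compound 2 to compound 3 is expected to be an at least 1.2-fold lower number from compound 2 to compound 3 (0.09 log units; that floor lies within the scatter), most likely still near the limit. Compound 3 is estimated at 8000 nM, within a range from 1000 nM to 30000 nM.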

Compound 3, half-maximal effective concentration: > 10000 nM
Compound 3: no number, only a limit; the forecaster's own chance of this, stated with the estimate: 60%; middle value at least 1.2-fold (0.09 log units) away from the limit.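

No step can be read from compound 2 to compound 3, as each gives only a limit of the assay and not a number: the limit of > 10000 nM in this assay, at which 3 of the 3 values shown sit.

The compounds shown leave open whether any group on the shared core, in place of 1-methyl-1H-pyrazol-5-yl or (ethylsulfonyl)amino, would give a measurable number in this assay.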